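Working notes: methyl step from compound 3 to compound 4

The source may report more compounds than this note shows. Statements on the series, on what has been measured and on what is new or still open speak of the compounds shown alone.

Measured so far in a functional assay on HT-29 cells (Homo sapiens) for cytotoxicity, read by MTT assay, with a stated time of 24 h; a higher number here means a weaker inhibitor, a lower number a stronger inhibitor:
compound 1 `CN(C)CCN1CCN(CC(=O)Nc2ccc(-c3nc4cc(F)ccc4o3)cc2)CC1`; compound 1 gives 8190 nM
compound 2 `Cc1cc(-c2nc3ccccc3o2)ccc1NC(=O)CN1CCN(CCN(C)C)CC1`; compound 2 gives 12900 nM
compound 3 `CN(C)CCN1CCN(CC(=O)Nc2ccc(-c3nc4cc(Cl)ccc4o3)cc2)CC1`; compound 3 gives 4470 nM

Compound 3 carries the lowest of the three numbers. Compound 1 is nearest to it and sits within the scatter; compound 2 is furthest and lies beyond the scatter. Within the data shown here, the only single-point step among the measured compounds, a 1.8-fold lower number from compound 1 to compound 3 (0.26 log units; within the scatter), is itself within the scatter.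

Compound 4 `Cc1cc(-c2nc3cc(Cl)ccc3o2)ccc1NC(=O)CN1CCN(CCN(C)C)CC1` differs from compound 3 by methyl in place of hydrogen on an aromatic carbon. Among the measured compounds shown here, no measured pair isolates this change. Compound 1 and compound 2 differ in two places, one of them this same methyl for hydrogen, and their two numbers lie within the scatter of each other; the pair shows nothing more. For the measured compounds named here, with no step bearing directly on the change, no shift beyond the scatter is expected in this assay. The estimate for compound 4 is 5500 nM, with a range of 2200 nM to 14000 nM. The expected step is a 1.2-fold higher number from compound 3 to compound 4 (0.09 log units; within the scatter), a change not expected to exceed the scatter.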

Compound 4, half-maximal inhibitory concentration: 13200 nM
The estimate for compound 4 lay 2.4-fold (0.38 log units) below the measured number; the range from low to high includes it.
By their numbers in this assay, from the lowest: compounds 3, 1, 2 and 4 (each within the scatter of the next, the first and the last beyond it).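

In this assay, among these compounds, methyl in place of hydrogen on this aromatic carbon, ortho to a large group, now has a direct reading: a 3.0-fold higher number from compound 3 to compound 4 (0.47 log units; beyond the scatter), a modest step that no earlier pair isolated. With the methyl present, chloro in place of hydrogen leaves the number within the scatter, at a 1.0-fold higher number from compound 2 to compound 4 (0.01 log units; within the scatter), so the methyl step is the only one of the two new steps that lies beyond it. Nothing available explains the methyl step.

On these data alone, it remains open whether ethyl, methoxy or an amine on the same aromatic carbon would give a step of similar size. This single pair also leaves open whether the methyl step would recur with fluoro in place of chloro.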